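Chloro to bromo exchange on the shared core

The source may hold more compounds than are shown below. What is called first, only, known or untested is meant among the compounds shown, and "the series" means these compounds.

Measured so far:
compound 1 `Cc1ccc(S/C(=C/c2ccc(Cl)cc2)C(=O)c2ccc(Cl)cc2)cc1` gives 10000 nM in a functional assay on DU-145 cells (Homo sapiens) for inhibition, read by trypan blue exclusion, with a stated time of 96 h; on this read-out lower numbers stand for stronger inhibition of growth and higher numbers for weaker inhibition of growth
compound 2 `Cc1ccc(S/C(=C/c2ccc(-c3ccccc3)cc2)C(=O)c2ccc(Cl)cc2)cc1` gives 50000 nM in this assay

Going by the values given here, compound 1 holds the lower of the two numbers; the one measured step, a 5.0-fold higher number from compound 1 to compound 2 (0.70 log units; beyond the scatter), is phenyl in place of chloro on an aromatic carbon. Compound 3 `Cc1ccc(S/C(=C/c2ccc(Cl)cc2)C(=O)c2ccc(Br)cc2)cc1` differs from compound 1 by bromo in place of chloro on an aromatic carbon. Among the compounds with values here, that measured step concerns a different ring and a different group, so no measured step bears directly on a bromo for chloro swap. One halogen replaces another on the same aromatic carbon, so the expected step is no change at the digits printed from compound 1 to compound 3 (within the scatter), none beyond the scatter. Compound 3 is estimated at 10000 nM, in the range 4000 nM to 25000 nM.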

Compound 3, concentration for 50% growth inhibition: 10000 nM
Compound 3: the middle estimate sits on the measured number at the digits printed; the measured number falls inside the stated range.
By their numbers in this assay, from the lowest: compounds 1 and 3 (each within the scatter of the next); then compound 2.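

Bromo in place of chloro on this aromatic carbon gives no change at the digits printed from compound 1 to compound 3 (within the scatter) in this assay, the first measured step at this position. Going by these compounds alone, the earlier phenyl for chloro step lay on the other ring, so this is the first sign that one halogen can stand in for the other here without a step beyond the scatter. Nothing at hand bears on the reason for this result. 

Still open, from the compounds shown here alone, is whether an amine or a carboxylic acid on this carbon would stay within the scatter of compound 1.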